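From furan-3-yl to thiophen-2-yl on the shared core

This account rests on a few compounds, and the source may have more. Where it says the series, first, only, none or still open, it means among the compounds named here.

In a functional assay on K562 cells (Homo sapiens), read by MTT assay, with a stated time of 72 h (a lower number here means a stronger inhibitor, a higher number a weaker inhibitor), compound 3 `CNc1ncnc2c1c(-c1ccoc1)cn2[C@@H]1O[C@H](CO)[C@@H](O)[C@H]1O` gives > 20000 nM, which is a limit and not a number. Compound 3 thus stands at the limit of > 20000 nM in this assay, at which 2 of the 3 values shown sit. Compound 1 `CSc1ncnc2c1c(-c1cccs1)cn2[C@@H]1O[C@H](CO)[C@@H](O)[C@H]1O` gives > 20000 nM, also a limit. For the measured compounds named here, compound 2 `CNc1ncnc2c1c(-c1ccco1)cn2[C@@H]1O[C@H](CO)[C@@H](O)[C@H]1O` gives the only true number so far, 15100 nM.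

Compound 4 `CNc1ncnc2c1c(-c1cccs1)cn2[C@@H]1O[C@H](CO)[C@@H](O)[C@H]1O` carries thiophen-2-yl in place of furan-3-yl on an aromatic carbon. Going by the values given here, the one measured step at this place is an at least 1.3-fold higher number from compound 2 to compound 3 (0.12 log units; that floor lies within the scatter), so it fixes no size for a change of this group. Compound 1 bears the same thiophen-2-yl as compound 4, but it differs elsewhere and reached only a limit. In this assay, no step beyond the scatter is therefore expected, though a small move towards a lower number remains possible, and a limit is about as likely as a number. The expected step is an at least 1.2-fold lower number from compound 3 to compound 4 (0.09 log units; that floor lies within the scatter). For compound 4 the estimated value is 16000 nM, with an expected range of 7000 nM to 30000 nM.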

Compound 4, half-maximal inhibitory concentration: > 20000 nM
Compound 4 gave a limit, no number; the forecaster's own chance of this, stated with the estimate: 55%; middle value at least 1.2-fold (0.09 log units) from the limit.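

With methylamino kept on the shared core, thiophen-2-yl on this aromatic carbon leaves compound 4 at a limit in this assay, so the change from furan-3-yl yields no number. For the compounds shown here, the only readable step is an at least 1.3-fold higher number from compound 2 to compound 4 (0.12 log units; that floor lies within the scatter), so this floor does not separate thiophen-2-yl from furan-2-yl, and the steps from compound 3 and from compound 1 cannot be read because both ends are limits. Most of the compounds shown now sit at the same edge of the assay: the limit of > 20000 nM in this assay, at which 3 of the 4 values shown sit.

On these data alone, what stays open is whether any group at this place gives a clearly lower number than compound 2 at 15100 nM. A phenyl ring or a pyridine ring here might answer that, and the compounds shown do not.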